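The source may hold more compounds than are shown below. What is called first, only, known or untested is meant among the compounds shown, and "the series" means these compounds.

Compound 1 `c1ccc2[nH]c(-n3cccn3)cc2c1`: 86000 nM
Compound 2 `COc1ccc2[nH]c(-c3ccc[nH]3)cc2c1`: 26000 nM
Compound 3 `COc1ccc2[nH]c(-n3cccn3)cc2c1`: 70000 nM

All three values come from a functional assay on LoVo cells (Homo sapiens) for cytotoxicity, read by MTT assay, with a stated time of 72 h; a higher number here means a weaker inhibitor, a lower number a stronger inhibitor. Compound 3 stands level with compound 1 within the scatter, while a 2.7-fold higher number from compound 2 to compound 3 (0.43 log units; beyond the scatter) separates it from compound 2. That second step swaps a different group, so it says little about the change considered here. Compound 4 `Cc1ccc2[nH]c(-n3cccn3)cc2c1` carries methyl in place of methoxy on an aromatic carbon. The closest evidence is a 1.2-fold lower number from compound 1 to compound 3 (0.09 log units; within the scatter), which shows that methoxy and hydrogen at this carbon are not told apart by the measurement. Methyl is therefore not expected to move the number beyond the scatter either. The expected step is a 1.1-fold lower number from compound 3 to compound 4 (0.03 log units; within the scatter). For compound 4 the estimated value is 65000 nM, with an expected range from 30000 nM to 130000 nM.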

Compound 4, half-maximal inhibitory concentration: 87000 nM
Compound 4: the middle estimate sits 1.3-fold (0.13 log units) below what was measured; measured number inside the range.
By their numbers in this assay, from the lowest: compound 2; then compounds 3, 1 and 4 (each within the scatter of the next).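

The steps, a 1.2-fold higher number from compound 3 to compound 4 (0.09 log units; within the scatter) and a 1.0-fold higher number from compound 1 to compound 4 (0.01 log units; within the scatter), place hydrogen, methoxy and methyl on this aromatic carbon level with one another. The earlier compounds shown here compared only hydrogen and methoxy, so the silence of this position now extends to a carbon group with no hydrogen-bond acceptor. Nothing available here explains this flat result.

On these data alone, whether an amine, a carboxylic acid or a longer chain on this carbon would move the number remains open. Also open, as far as these compounds go, is whether methyl would behave alike with 1H-pyrrol-2-yl in place of 1H-pyrazol-1-yl.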